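Swapping Ethyl for Bromo on the Phenyl Ring

The source may hold more compounds than are shown below. What is called first, only, known or untested is meant among the compounds shown, and "the series" means these compounds.

Within the data shown here, compound 2 `CCc1ccc(C(CCN2CCN(c3ccccc3OC)CC2)Oc2ccc(C(=O)Nc3ccccc3OCCCC(=O)O)cc2)cc1` gives 70 nM in an assay on isolated protein for inhibition of steroid 5-alpha-reductase (Rattus norvegicus) (on this read-out higher numbers stand for weaker inhibition and lower numbers for stronger inhibition), the lowest of the two numbers measured so far. Compound 1 `COc1ccccc1N1CCN(CCC(Oc2ccc(C(=O)Nc3ccccc3OCCCC(=O)O)cc2)c2ccccc2)CC1` differs from it only in carrying hydrogen where compound 2 carries ethyl, and in this assay compound 1 gives 1000 nM. The resulting step, a 14-fold lower number from compound 1 to compound 2 (1.15 log units; beyond the scatter), is large and clearly beyond the usual scatter.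

Compound 3 `COc1ccccc1N1CCN(CCC(Oc2ccc(C(=O)Nc3ccccc3OCCCC(=O)O)cc2)c2ccc(Br)cc2)CC1` alters the same spot once more: bromo in place of ethyl on an aromatic carbon, on an aromatic carbon of a six-membered aromatic ring of carbon only, para to a large group. Among the measured compounds shown here, only the step already described bears on this change. For the measured compounds named here, it shows that what sits on this carbon matters greatly, but no measurement tells how bromo compares with ethyl there, so the outcome could fall anywhere between the two known numbers. Compound 3 is therefore expected at 150 nM, within 40 nM to 600 nM, an estimated step of a 2.1-fold higher number from compound 2 to compound 3 (0.33 log units; beyond the scatter).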

Compound 3, half-maximal inhibitory concentration: 210 nM
Compound 3: middle estimate off by 1.4-fold (0.15 log units), on the low side; the measured number falls inside the stated range.
By their numbers in this assay, from the lowest: compound 2; then compound 3; then compound 1.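

In this assay, bromo on this aromatic carbon also beats plain hydrogen (a 4.8-fold lower number from compound 1 to compound 3 (0.68 log units; beyond the scatter)), so the gain is not confined to ethyl, at least across these two groups. The two groups are not interchangeable, however: ethyl keeps the lower number, and going over to bromo gives up part of its gain (a 3.0-fold higher number from compound 2 to compound 3 (0.48 log units; beyond the scatter)). Nothing measured here explains the difference between ethyl and bromo.

From the compounds shown here alone, it remains open whether an alkyl group of another length, such as methyl or propyl, would do better or worse than ethyl, and whether chloro or fluoro would land near bromo. Going by these compounds, it is also open whether ethyl or bromo would give a similar gain on another carbon of this ring.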